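Compound 3 to compound 4: swapping the aryl group

The source may hold more compounds than are shown below. What is called first, only, known or untested is meant among the compounds shown, and "the series" means these compounds.

Compound 1 `CCOC(=O)C1=C(C)N=C(C)N(C(=O)OCC)C1c1ccccc1[N+](=O)[O-]`: 0.00667 h
Compound 2 `CCCCCCCOC(=O)N1C(C)=NC(C)=C(C(=O)OCC2CC2)C1c1ccccc1[N+](=O)[O-]`: 0.0833 h
Compound 3 `CCC1N=C(C)/C(=C(/O)OC(C)C)C(c2ccccc2[N+](=O)[O-])N1C(=O)OCN(Cc1ccccc1)Cc1ccc2ccccc2c1`: 0.142 h

In an ADME assay on the whole organism with Canis familiaris (Canis lupus familiaris) as the target (a higher number here means that the compound lasts longer, a lower number that the compound disappears faster), compound 3 sits within the usual scatter of compound 2 and lies beyond the scatter above compound 1.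

Compound 4 `CCC1N=C(C)/C(=C(/O)OC(C)C)C(c2ccccc2[N+](=O)[O-])N1C(=O)OCN(Cc1ccccc1)Cc1ccc(Cl)c(Cl)c1` carries 3,4-dichlorophenyl in place of naphthalen-2-yl on a saturated chain carbon bound to an amine nitrogen. Within the data shown here, no measured pair isolates this change, so the data offer no direct guide. No step beyond the scatter is expected in this assay. The expected change is small, an estimated 1.2-fold lower number from compound 3 to compound 4 (0.07 log units; within the scatter). The estimate for compound 4 is 0.12 h, with an expected range of 0.05 h to 0.28 h.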

Compound 4, half-life: 0.333 h
Compound 4: middle estimate off by 2.8-fold (0.44 log units), on the low side, outside the stated range (above it).
By their numbers in this assay, from the lowest: compound 1; then compounds 2 and 3 (each within the scatter of the next); then compound 4.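

In this assay, among these compounds, this is the first single change that can be read: 3,4-dichlorophenyl in place of naphthalen-2-yl, on a saturated chain carbon bound to an amine nitrogen, gives a 2.3-fold higher number from compound 3 to compound 4 (0.37 log units; beyond the scatter) and lies beyond the scatter. The aryl group at this place therefore does affect half-life, and here the single aromatic ring outlasts the two-ring group. Nothing measured accounts for the step.

Open, from the compounds shown here alone, is whether the chlorine atoms or the loss of the second ring carries the step. A 4-chlorophenyl or 3-chlorophenyl group at the same place would separate the two.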